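Trifluoromethylsulfonyl in place of methylsulfonyl on compound 2

The source may report more compounds than this note shows. Statements on the series, on what has been measured and on what is new or still open speak of the compounds shown alone.

Compound 2 `COc1cc(NC(=O)c2ccc(Cl)cc2)ccc1NS(C)(=O)=O` gives 70000 nM in an ADME assay on RAW264.7 cells (Mus musculus) for cytotoxicity, read by MTT assay, with a stated time of 48 h; on this read-out higher numbers stand for weaker inhibition and lower numbers for stronger inhibition. Of the two numbers in hand it is the higher one; compound 1 `Cc1cc(NC(=O)c2ccc(Cl)cc2)ccc1NS(=O)(=O)C(F)(F)F` gives 35400 nM, and that gap from compound 2 lies within the scatter. Compound 3 `COc1cc(NC(=O)c2ccc(C#N)cc2)ccc1NS(C)(=O)=O` gives only a limit in this assay, > 250000 nM, which is the limit of > 250000 nM in this assay, at which 1 of the 3 values shown sits. Within the data shown here, the one step that can be followed, an at least 3.5-fold higher number from compound 2 to compound 3 (0.55 log units; beyond the scatter), changes the aryl group on the amide side and not the sulfonyl group, so it says little about the change considered here. Compound 4 `COc1cc(NC(=O)c2ccc(Cl)cc2)ccc1NS(=O)(=O)C(F)(F)F` differs from compound 2 in one place: trifluoromethyl in place of methyl on a sulfonyl sulfur. Among the measured compounds shown here, compound 1 already carries the trifluoromethyl on its sulfonyl sulfur, though with a methyl rather than a methoxy on the core, and its value and that of compound 2 sit within the scatter of one another; there is thus no measured step that points to a shift beyond the scatter for this change. The expected step is therefore a 1.6-fold lower number from compound 2 to compound 4 (0.19 log units; within the scatter), no larger than the scatter and leaning slightly toward the number of compound 1. For compound 4 the estimate in this assay is 45000 nM, between 15000 nM and 130000 nM.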

Compound 4, half-maximal inhibitory concentration: 108000 nM
For compound 4 the middle estimate is 2.4-fold (0.38 log units) below the measured one; the measured number falls inside the stated range.
By their numbers in this assay, from the lowest: compounds 1, 2 and 4 (each within the scatter of the next, the first and the last beyond it). At a limit, above all of these: compound 3.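

In this assay the swap of methyl for trifluoromethyl on a sulfonyl sulfur, now measured directly with everything else held, gives a 1.5-fold higher number from compound 2 to compound 4 (0.19 log units; within the scatter) and so leaves no readable shift at this position. The same result opens a second comparison with the sulfonyl group held as trifluoromethylsulfonyl: methoxy in place of methyl on an aromatic carbon gives a 3.1-fold higher number from compound 1 to compound 4 (0.48 log units; beyond the scatter) and this modest step, unlike the sulfonyl change, stands clear of the scatter. Nothing among the measurements shown accounts for the size of either step.

The compounds shown leave open whether the sulfonyl sulfur takes groups other than these two without a readable shift, for example a longer chain such as ethyl, a phenyl ring or an amine in the place of methyl. Among these compounds, they also leave open whether nitrile in place of chloro on the aromatic carbon, so far seen only with methylsulfonyl, would shift the number in the same direction when trifluoromethylsulfonyl is present, and whether the methoxy-for-methyl step holds with methylsulfonyl.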